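A few compounds are considered here, and "the series" means these few. Any claim that something is new, unique, unknown or untested is made for them only; others in the source may bear on it.

Measured compounds:
Compound 1 `COC(=O)[C@@H](C)NC(=O)Cn1cc(C2=C(c3c[nH]c4ccccc34)C(=O)N(C)C2=O)c2ccccc21` gives 30500 nM in a functional assay on A549 cells (Homo sapiens) for cytotoxicity, read by MTT assay, with a stated time of 24 h; on this read-out lower numbers stand for stronger inhibition and higher numbers for weaker inhibition.
Compound 2 `COC(=O)[C@@H](CO)NC(=O)Cn1cc(C2=C(c3c[nH]c4ccccc34)C(=O)N(C)C2=O)c2ccccc21` gives 37900 nM in this assay.

Compound 2 stands with the highest of the two numbers in this assay, and its nearest neighbour is compound 1, since the step of a 1.2-fold higher number from compound 1 to compound 2 (0.09 log units; within the scatter) is within the scatter. The two compounds therefore show no distinguishable difference on this read-out.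

Compound 3 `COC(=O)[C@@H](CC(C)C)NC(=O)Cn1cc(C2=C(c3c[nH]c4ccccc34)C(=O)N(C)C2=O)c2ccccc21` has not yet been measured in this assay. It differs from compound 2 by isopropyl in place of hydroxy on a saturated chain carbon, two bonds along the chain from an amide-type nitrogen and a carbonyl carbon. Within the data shown here, only one measured step touches this position: the step of a 1.2-fold higher number from compound 1 to compound 2 (0.09 log units; within the scatter), which exchanged hydrogen for hydroxy and left the number essentially unchanged. Among the measured compounds shown here, no measured pair shows what an isopropyl group does at this position, so the expectation rests on the small size of that single step. Because a 1.2-fold higher number from compound 1 to compound 2 (0.09 log units; within the scatter) was within the scatter, the estimate for compound 3 is a step of a 1.2-fold lower number from compound 2 to compound 3 (0.07 log units; within the scatter), that is, no change beyond the scatter in either direction. Compound 3 is therefore expected to give about 32000 nM in this assay, within a range of 12000 nM to 85000 nM.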

Compound 3, half-maximal inhibitory concentration: > 100000 nM
Compound 3: only a limit was reported (the forecaster's own chance of this, stated with the estimate: 10%); middle value at least 3.1-fold (0.49 log units) away from the limit.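

In this assay, compound 3 gave no number, only a limit of the assay: the limit of > 100000 nM in this assay, at which 1 of the 3 values shown sits.

This limit still shows that the position on the saturated chain carbon, two bonds along the chain from an amide-type nitrogen and a carbonyl carbon, is not indifferent to what it carries, since isopropyl in place of hydroxy gives an at least 2.6-fold higher number from compound 2 to compound 3 (0.42 log units; beyond the scatter) and isopropyl in place of hydrogen gives an at least 3.2-fold higher number from compound 1 to compound 3 (0.51 log units; beyond the scatter). Among these compounds, the earlier exchange of hydrogen for hydroxy had stayed within the scatter, so this is the first change at the position to go beyond it, and it goes towards weaker inhibition, with only a lower bound on its size.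

The compounds shown do not separate the larger count of heavy atoms in isopropyl from the loss of the hydroxy group's hydrogen-bond donor and acceptor, as both change in the same step. They also leave open how a straight ethyl or propyl chain, an aminomethyl group or a carboxylic acid would read at this position, and so whether the rise in the number grows gradually with chain length or appears only with the branched isobutyl side chain.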